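Halogen exchange on the aryl ring of compound 2

A few compounds are considered here, and "the series" means these few. Any claim that something is new, unique, unknown or untested is made for them only; others in the source may bear on it.

Three compounds share one core and differ only in the aryl group. Compound 1 is `Nc1nc(NCCNc2ncc(-c3ncc[nH]3)c(-c3ccc(F)cc3F)n2)ccc1[N+](=O)[O-]`, compound 2 is `Nc1nc(NCCNc2ncc(-c3ncc[nH]3)c(-c3cc(F)ccc3F)n2)ccc1[N+](=O)[O-]`, and compound 3 is `Nc1nc(NCCNc2ncc(-c3ncc[nH]3)c(-c3ccc(F)cc3Br)n2)ccc1[N+](=O)[O-]`. In an ADME assay on microsomes from liver (Rattus norvegicus) for metabolic stability (on this read-out higher numbers stand for a longer-lived compound and lower numbers for a shorter-lived compound), compound 1 reaches the limit of the read-out, > 0.5 h. In this assay compound 2 likewise sits at a limit, > 0.5 h. Compound 3 also gives only a limit, > 0.5 h. Compound 2 therefore stands at the same limit as the other two, and no number separates them, because of the limit of > 0.5 h in this assay, at which 3 of the 3 values shown sit.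

Compound 4 is `Nc1nc(NCCNc2ncc(-c3ncc[nH]3)c(-c3ccc(Cl)cc3Br)n2)ccc1[N+](=O)[O-]`; it carries 2-bromo-4-chlorophenyl in place of 2,5-difluorophenyl on an aromatic carbon. The measured steps that bear on this are a step that the two limits leave unreadable from compound 2 to compound 3 and a step that the two limits leave unreadable from compound 1 to compound 3, which also introduce bromo at this position, and a step that the two limits leave unreadable from compound 1 to compound 2; all three are unreadable because both ends sit at the limit. Compound 4 is expected to behave in the same way, with a step that the limit leaves unreadable from compound 2 to compound 4 from compound 2 that is more likely to land at the limit than at a readable number. Compound 4 is thus estimated at 1.5 h, within 0.5 h to 5 h.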

Compound 4, half-life: > 0.5 h
Compound 4 ended at the assay's limit; the forecaster's own chance of this, stated with the estimate: 80%; the middle value is on the limit's open side.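

In this assay, for the compounds shown here, compound 4 joins compounds 1, 2 and 3 at the limit, so no step from compound 4 to any of them can be read: the limit of > 0.5 h in this assay, at which 4 of the 4 values shown sit. The compounds shown leave open how far each half-life extends past that limit, and whether these aryl changes alter it at all.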